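Methoxycarbonyl to Allyloxycarbonyl: An Expected Antiproliferative Result

The source may hold more compounds than are shown below. What is called first, only, known or untested is meant among the compounds shown, and "the series" means these compounds.

Compound 1 `C/C=C1/[C@H](O[C@@H]2O[C@H](COC(C)=O)[C@@H](OC(C)=O)[C@H](OC(C)=O)[C@H]2OC(C)=O)OC=C(C(=O)OC)[C@H]1CC(=O)O` gives in a functional assay on SK-BR-3 cells (Homo sapiens) for antiproliferative activity, read by MTT assay, with a stated time of 72 h (a higher number here means a weaker inhibitor, a lower number a stronger inhibitor), only a limit, > 15000 nM.
Compound 2 `C/C=C1/[C@H](O[C@@H]2O[C@H](COC(C)=O)[C@@H](OC(C)=O)[C@H](OC(C)=O)[C@H]2OC(C)=O)OC=C(C(=O)OC)[C@H]1CC(=O)OCCC1CCCCC1` gives in this assay only a limit, > 15000 nM.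
Compound 3 `C/C=C1/[C@H](O[C@@H]2O[C@H](COC(C)=O)[C@@H](OC(C)=O)[C@H](OC(C)=O)[C@H]2OC(C)=O)OC=C(C(=O)OC)[C@H]1CC(=O)OC` gives in this assay only a limit, > 15000 nM.

Compound 3 therefore stands at a limit of this assay and not at a number. Within the data shown here, the same holds for every value measured so far: the limit of > 15000 nM in this assay, at which 3 of the 3 values shown sit. Compound 4 `C=CCOC(=O)C[C@@H]1C(C(=O)OC)=CO[C@@H](O[C@@H]2O[C@H](COC(C)=O)[C@@H](OC(C)=O)[C@H](OC(C)=O)[C@H]2OC(C)=O)/C1=C/C` is the next member of the series, and it differs from compound 3 in one place: vinyl in place of hydrogen on a saturated chain carbon bound to an oxygen next to a carbonyl group.

Among the measured compounds shown here, three measured steps touch the same oxygen next to a carbonyl group. The step that the two limits leave unreadable from compound 1 to compound 3, the step that the two limits leave unreadable from compound 1 to compound 2 and the step that the two limits leave unreadable from compound 2 to compound 3 all run between values that are limits, so none of them can be read as a size or a direction. Nothing in the shared core changes between compound 3 and compound 4, and the measured record gives no sign that a small change at this ester oxygen moves the read-out into the range where numbers appear.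

Compound 4 is therefore expected to stay at the limit of this assay, with the step that the limit leaves unreadable from compound 3 to compound 4 expected to show nothing beyond the scatter. The estimate for compound 4 is 25000 nM, with a range from 10000 nM to 60000 nM.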

Compound 4, half-maximal inhibitory concentration: > 20000 nM
Compound 4 gave a limit, no number; the forecaster's own chance of this, stated with the estimate: 85%; the middle value lies beyond the limit too.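

In this assay compound 4 gives > 20000 nM, which is a limit and not a number. Among these compounds, compound 1, compound 2 and compound 3 also stand only at limits, so no step to compound 4 can be read. The compounds shown leave open whether any real difference in strength separates these four compounds.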